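A few compounds are considered here, and "the series" means these few. Any claim that something is new, unique, unknown or untested is made for them only; others in the source may bear on it.

Going by the values given here, the three compounds measured so far share one core and differ only in a single group. Compound 1 `CCO/C(O)=C1\C(COCCNC(C)=O)=NC(C)=C(C(=O)OC)C1c1ccccc1Cl` gives 15.9 nM in a functional assay (aorta) with Rattus norvegicus as the target; on this read-out lower numbers stand for stronger inhibition and higher numbers for weaker inhibition. Compound 2 `CCO/C(O)=C1\C(COCCNC(=O)NC)=NC(C)=C(C(=O)OC)C1c1ccccc1Cl` gives 3.16 nM in this assay, and compound 3 `CCO/C(O)=C1\C(COCC/N=C(/NC)NC#N)=NC(C)=C(C(=O)OC)C1c1ccccc1Cl` gives 6.31 nM. Compound 1 thus stands highest of the three numbers; the nearest is compound 3 and the furthest compound 2, both at a distance beyond the scatter.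

Compound 4 `CCO/C(O)=C1\C(COCCNC(C)C(N)=O)=NC(C)=C(C(=O)OC)C1c1ccccc1Cl` has not yet been measured. It differs from compound 1 in one place: 1-carbamoylethyl in place of acetyl on an amine nitrogen. Seen a little further out, acetamido becomes (1-carbamoylethyl)amino.

Among the compounds with values here, two measured steps bear on this. a 5.0-fold lower number from compound 1 to compound 2 (0.70 log units; beyond the scatter) came from methylamino in place of methyl on a carbonyl carbon. a 2.5-fold lower number from compound 1 to compound 3 (0.40 log units; beyond the scatter) came from a larger group in the same part of the chain. Both changes to this same part of compound 1 lowered the number, yet neither is the same as the change that leads to compound 4. The step of a 2.0-fold lower number from compound 1 to compound 4 (0.30 log units; within the scatter) is therefore expected to be a modest lowering, with a real chance that it falls within the scatter. Compound 4 is estimated at 8 nM, in the range 3 nM to 25 nM.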

Compound 4, half-maximal inhibitory concentration: 10 nM
Compound 4: middle estimate off by 1.3-fold (0.10 log units), on the low side, within the range that was stated.
By their numbers in this assay, from the lowest: compounds 2, 3, 4 and 1 (each within the scatter of the next, the first and the last beyond it).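

In this assay, putting 1-carbamoylethyl in place of acetyl on the amine nitrogen gives a 1.6-fold lower number from compound 1 to compound 4 (0.20 log units; within the scatter), so this replacement cannot be told apart from the acetyl group of compound 1. The comparison with the cyano-bearing group gives a 1.6-fold higher number from compound 3 to compound 4 (0.20 log units; within the scatter), which also cannot be separated, whereas the comparison with methylcarbamoyl gives a 3.2-fold higher number from compound 2 to compound 4 (0.50 log units; beyond the scatter), the only clear difference among the new steps. The clear gain seen earlier with methylcarbamoyl in place of acetyl therefore does not come with every replacement of acetyl on this nitrogen, and this position tolerates a non-acyl group of 5 heavy atoms without a clear loss.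

From the compounds shown here alone, what remains open is which part of 1-carbamoylethyl matters, since its methyl branch and its terminal amide always appear together here. A carbamoylmethyl group, which lacks the branch, or a 1-carboxyethyl group, with a carboxylic acid in place of the amide, would pull those two parts apart. Nothing in the data given explains why these groups compare as they do.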